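The source may report more compounds than this note shows. Statements on the series, on what has been measured and on what is new or still open speak of the compounds shown alone.

Three compounds have been measured in a functional assay on LOX IMVI cells (Homo sapiens) for inhibition, read by sulforhodamine B assay, with a stated time of 48 h; a higher number here means a weaker inhibitor of growth, a lower number a stronger inhibitor of growth:

compound 1 `COc1cc(-c2cc(/C=C/C(=O)c3ccc(N)cc3)[nH]n2)cc(OC)c1OC` gives 3280 nM
compound 2 `COc1cc(-c2cc(/C=C/C(=O)c3ccc(Cl)c(Cl)c3)[nH]n2)cc(OC)c1OC` gives 16400 nM
compound 3 `COc1ccc(C(=O)/C=C/c2cc(-c3cc(OC)c(OC)c(OC)c3)n[nH]2)cc1` gives 3020 nM

Compound 3 and compound 1 stand together, their gap within the scatter (a 1.1-fold lower number from compound 1 to compound 3 (0.04 log units; within the scatter)). Compound 2 stands apart from both with a higher number (a 5.0-fold higher number from compound 1 to compound 2 (0.70 log units; beyond the scatter)).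

Compound 4 `COc1cc(-c2cc(/C=C/C(=O)c3ccc(F)c(F)c3)[nH]n2)cc(OC)c1OC` has not yet been measured. It differs from compound 3 in one place: 3,4-difluorophenyl in place of 4-methoxyphenyl on a carbonyl carbon. Within the data shown here, the steps that bear on this are the two that involve the 3,4-dichlorophenyl of compound 2, which sits on the same carbonyl carbon; the step from that group to the group of compound 3 was a 5.4-fold lower number from compound 2 to compound 3 (0.73 log units; beyond the scatter). The 3,4-difluorophenyl of compound 4 shares with that group the two halogens on the same ring positions, so a higher number is expected for compound 4 in this assay, though fluorine is a different halogen and the step is expected to be smaller: a 3.0-fold higher number from compound 3 to compound 4 (0.47 log units; beyond the scatter). Compound 4 is therefore estimated at 9000 nM, with a range from 3500 nM to 24000 nM.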

Compound 4, concentration for total growth inhibition: 12200 nM
Compound 4: middle estimate off by 1.4-fold (0.13 log units), on the low side; low and high end bracket the measured number.
By their numbers in this assay, from the lowest: compounds 3 and 1 (each within the scatter of the next); then compounds 4 and 2 (each within the scatter of the next).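

In this assay, exchanging one halogen for the other on this ring makes little difference, a 1.3-fold lower number from compound 2 to compound 4 (0.13 log units; within the scatter), so the 3,4-difluorophenyl and the 3,4-dichlorophenyl on the carbonyl carbon stand together. The steps to compound 4 from the other two compounds lie beyond the scatter, a 4.0-fold higher number from compound 3 to compound 4 (0.61 log units; beyond the scatter) and a 3.7-fold higher number from compound 1 to compound 4 (0.57 log units; beyond the scatter), so among these four compounds the two halogen-bearing rings stand apart from the 4-methoxyphenyl and the 4-aminophenyl, and no compound goes against this. No measurement is given that could account for this split. The compounds shown leave open whether a ring with a single halogen, such as 4-fluorophenyl, would stand with the 3,4-difluorophenyl or with the 4-methoxyphenyl. They also leave open where an unsubstituted phenyl or a ring carrying a carboxylic acid would fall at this place.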